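Moving the halogen on the carbonyl's phenyl ring

The source may hold more compounds than are shown below. What is called first, only, known or untested is meant among the compounds shown, and "the series" means these compounds.

Three measured compounds share one core and differ only in the group on the ring nitrogen. In a functional assay on MCF7 cells (Homo sapiens) for inhibition, read by MTT assay, with a stated time of 48 h (on this read-out lower numbers stand for stronger inhibition and higher numbers for weaker inhibition), compound 1 `COc1cc(N(Cc2nc3ccccc3[nH]2)S(=O)(=O)c2ccc(C)cc2)cc(OC)c1OC` gives 5400 nM, while compound 2 `COc1cc(N(Cc2nc3ccccc3[nH]2)C(=O)c2ccc(F)cc2)cc(OC)c1OC` gives 45200 nM, a change summarised as an 8.4-fold higher number from compound 1 to compound 2 (0.92 log units; beyond the scatter). Compound 3 `COc1cc(N(Cc2nc3ccccc3[nH]2)C(=O)c2ccc(Br)cc2)cc(OC)c1OC` reaches only the limit > 50000 nM in this assay, so for it no number is known. Compound 4 `COc1cc(N(Cc2nc3ccccc3[nH]2)C(=O)c2cccc(Cl)c2)cc(OC)c1OC` carries 3-chlorophenyl in place of 4-bromophenyl on a carbonyl carbon. The closest measured step, an at least 1.1-fold higher number from compound 2 to compound 3 (0.04 log units; that floor lies within the scatter), lay within the scatter, and both carbonyl compounds sit far from compound 1, as an at least 9.2-fold higher number from compound 1 to compound 3 (0.96 log units; beyond the scatter) shows. A step of a number no higher from compound 3 to compound 4 (the limit leaves the size open) is therefore expected. Compound 4 is estimated at 50000 nM in this assay, between 18000 nM and 150000 nM, quite possibly again only a limit.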

Compound 4, half-maximal inhibitory concentration: 34900 nM
Compound 4: middle estimate off by 1.4-fold (0.16 log units), on the high side; the range from low to high includes it.
By their numbers in this assay, from the lowest: compound 1; then compounds 4 and 2 (each within the scatter of the next). At a limit, above all of these: compound 3.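

With 3-chlorophenyl on the carbonyl carbon, the series gains a measured value that can be compared with compound 2, and a 1.3-fold lower number from compound 2 to compound 4 (0.11 log units; within the scatter) shows no difference between them in this assay. Compound 3 stands at a limit of the assay: the limit of > 50000 nM in this assay, at which 1 of the 4 values shown sits. Its step therefore gives only a floor, an at least 1.4-fold lower number from compound 3 to compound 4 (0.15 log units; that floor lies within the scatter), while a 6.5-fold higher number from compound 1 to compound 4 (0.81 log units; beyond the scatter) shows compound 4 also sitting apart from the sulfonyl compound.

Halogen and ring place change together here, so neither can be credited alone. On these data alone, what an amine or a carboxylic acid on this phenyl ring would do remains open.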